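Chloro-to-hydrogen swap on the fused ring and cytotoxicity

The source may report more compounds than this note shows. Statements on the series, on what has been measured and on what is new or still open speak of the compounds shown alone.

Compound 1 `CC(=O)c1sc(/N=C2\NC(=O)/C(=C3/C(=O)N(C)c4ccc(Cl)cc43)S2)nc1C` and compound 2 `CC(=O)c1sc(/N=C2\NC(=O)/C(=C3/C(=O)N(C)c4ccccc43)S2)nc1C` share one core; compound 3 `CCOC(=O)c1sc(/N=C2\NC(=O)/C(=C3/C(=O)N(Cc4ccccc4)c4ccc(Cl)cc43)S2)nc1C` is built on another core, and the difference between the two cores is not broken down here. In an ADME assay on RAW264.7 cells (Mus musculus) for cytotoxicity (on this read-out higher numbers stand for weaker inhibition of growth and lower numbers for stronger inhibition of growth), compound 1 gives 125 ug/mL. Compound 2 reaches only an assay limit of > 250 ug/mL in this assay. Compound 3 gives 62.5 ug/mL in this assay, a number close to that of compound 1. The change hydrogen in place of chloro on an aromatic carbon went with an at least 2.0-fold higher number from compound 1 to compound 2 (0.30 log units; that floor lies within the scatter), one value sitting at the limit of > 250 ug/mL in this assay, at which 1 of the 3 values shown sits. Compound 4 `CCOC(=O)c1sc(/N=C2\NC(=O)/C(=C3/C(=O)N(Cc4ccccc4)c4ccccc43)S2)nc1C` is not yet measured and differs from compound 3 by hydrogen in place of chloro on an aromatic carbon, the same change at the same place. Compound 4 is expected to show a 2.0-fold higher number from compound 3 to compound 4 (0.30 log units; within the scatter) in this assay. That expectation rests on an at least 2.0-fold higher number from compound 1 to compound 2 (0.30 log units; that floor lies within the scatter). The estimate for compound 4 is 125 ug/mL.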

Compound 4, concentration for 50% growth inhibition: 500 ug/mL
Compound 4: middle estimate off by 4.0-fold (0.60 log units), on the low side; the measured number lies above the stated range.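

On the core of compound 3, hydrogen in place of chloro on an aromatic carbon gives an 8.0-fold higher number from compound 3 to compound 4 (0.90 log units; beyond the scatter) in this assay. The change goes with a higher number on both cores shown, but this sets no rule for other cores and does not show that the size of the step carries from one core to the other: the same change on two cores in this assay, an at least 2.0-fold higher number (0.30 log units; that floor lies within the scatter) from compound 1 to compound 2 and an 8.0-fold higher number (0.90 log units; beyond the scatter) from compound 3 to compound 4; the limit leaves it open whether they differ. The value of compound 2, > 250 ug/mL, is a limit of the assay.

Still open, as far as these compounds go, is how a fluoro or a methoxy group on the same aromatic carbon would read on either core. Also open, from the compounds shown here alone, is whether a carboxylic acid in place of the ethyl ester would alter the step.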